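Replacing nitro with fluoro: what the small steps suggest

This account rests on a few compounds, and the source may have more. Where it says the series, first, only, none or still open, it means among the compounds named here.

Compound 1 `CC1=NN(S(=O)(=O)c2ccccc2)C(c2cc(Br)ccc2O)C1` gives 55600 nM
Compound 2 `CC1=NN(S(=O)(=O)c2ccccc2C)C(c2cc(Br)ccc2O)C1` gives 48100 nM
Compound 3 `CC1=NN(S(=O)(=O)c2ccc([N+](=O)[O-])cc2)C(c2cc(Br)ccc2O)C1` gives 27300 nM

In a functional assay on SGC-7901 cells (Homo sapiens) for antiproliferative activity, read by MTT assay, with a stated time of 48 h (a higher number here means that more compound is needed for the effect, a lower number that less compound is needed), compound 3 gives 27300 nM and lies within the usual scatter of compound 2 at 48100 nM while standing clearly lower than compound 1.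

Compound 4 `CC1=NN(S(=O)(=O)c2ccc(F)cc2)C(c2cc(Br)ccc2O)C1` differs from compound 3 in one place. The change is fluoro in place of nitro on an aromatic carbon and in words it is fluoro in place of nitro on an aromatic carbon, para to a large group.

For the measured compounds named here, two measured steps bear on this. Methyl in place of hydrogen on an aromatic carbon gave a 1.2-fold lower number from compound 1 to compound 2 (0.06 log units; within the scatter) and is the weaker guide. Adding nitro gave a 2.0-fold lower number from compound 1 to compound 3 (0.31 log units; beyond the scatter) and matters more: nitro is the group that leaves, and part of that modest step may be undone. That points to a small move toward a higher number in this assay and not a large one. Going by the values given here, no measured compound carries fluoro, which leaves this expectation loose.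

The expected change is a 1.5-fold higher number from compound 3 to compound 4 (0.19 log units; within the scatter) as an estimate, and it would stay within the scatter. For compound 4 the estimated value is 42000 nM with an expected range from 22000 nM to 75000 nM in this estimate.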

Compound 4, half-maximal effective concentration: > 60000 nM
Compound 4: only a limit was reported; the forecaster's own chance of this, stated with the estimate: 3%; middle value at least 1.4-fold (0.15 log units) from the limit.
By their numbers in this assay, from the lowest: compounds 3, 2 and 1 (each within the scatter of the next, the first and the last beyond it). At a limit, above all of these: compound 4.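

Compound 4 is reported in this assay only as a limit, not as a number: the limit of > 60000 nM in this assay, at which 1 of the 4 values shown sits. Even so, the change at this position can be read, since fluoro in place of nitro gives an at least 2.1-fold higher number from compound 3 to compound 4 (0.34 log units; beyond the scatter), so the lower number of compound 3 does not survive this swap and the step is beyond the scatter. The two other comparisons say less: fluoro in place of hydrogen gives an at least 1.0-fold higher number from compound 1 to compound 4 (0.03 log units; that floor lies within the scatter) and 4-fluorophenyl in place of 2-methylphenyl gives an at least 1.2-fold higher number from compound 2 to compound 4 (0.09 log units; that floor lies within the scatter), and both floors lie within the scatter, so fluoro at this position cannot yet be told apart from hydrogen or from the methyl group of the other compound.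

As far as these compounds go, the true value of compound 4 stays unknown, which leaves open whether fluoro is merely no help here or actually worse than hydrogen. From the compounds shown here alone, it also remains open whether the step seen with nitro belongs to nitro alone, a question that a nitrile, an amine or a carboxylic acid at this same position could answer.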